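This account rests on a few compounds, and the source may have more. Where it says the series, first, only, none or still open, it means among the compounds named here.

Compounds measured so far:
compound 1, `CN(C)c1ccc(-c2cccc(N)c2)cc1` — 100000 nM
compound 2, `CN(C)C(=O)Nc1cccc(-c2ccc(N(C)C)cc2)c1` — < 5000 nM

In an assay on COS-7 cells for inhibition of patatin-like phospholipase domain-containing protein 2 (Mus musculus) (a lower number here means a stronger inhibitor, a higher number a weaker inhibitor), compound 1 gives 100000 nM. Compound 2 reaches only a limit of the assay, < 5000 nM, so its true value is not known. The step of an at least 20-fold lower number from compound 1 to compound 2 (1.30 log units; beyond the scatter) is the only one measured; it sits at the limit of < 5000 nM in this assay, at which 1 of the 2 values shown sits. Compound 3, `CN(C)C(=O)N(C)c1cccc(-c2ccc(N(C)C)cc2)c1`, differs from compound 2 by methyl in place of hydrogen on an amide-type nitrogen. No measured step concerns a change on an amide-type nitrogen, so the step from compound 2 to compound 3 in this assay cannot be read from the numbers shown; a step that the limit leaves unreadable from compound 2 to compound 3 is assumed as the working expectation. Compound 3 is estimated at 3000 nM, with a range from 300 nM to 30000 nM.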

Compound 3, half-maximal inhibitory concentration: 70000 nM
The estimate for compound 3 lay 23-fold (1.37 log units) below the measured number; the measured number lies above the stated range.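

In this assay, methyl in place of hydrogen on the amide-type nitrogen gives an at least 14-fold higher number from compound 2 to compound 3 (1.14 log units; beyond the scatter), so this hydrogen cannot be replaced by methyl without a large loss. With the methyl present, the dimethylcarbamoyl group no longer separates from the parent amine: a 1.4-fold lower number from compound 1 to compound 3 (0.15 log units; within the scatter). The value of compound 2 is a limit of the assay, so the loss has only a lower bound: the limit of < 5000 nM in this assay, at which 1 of the 3 values shown sits.

Still open, going by these compounds, is whether ethyl on this nitrogen behaves like methyl. Also open, on these data alone, is whether acetyl in place of dimethylcarbamoyl, with the hydrogen kept, retains the gain seen for compound 2.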